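Extending a Fluorinated Chain in a Cytotoxicity Series

A few compounds are considered here, and "the series" means these few. Any claim that something is new, unique, unknown or untested is made for them only; others in the source may bear on it.

Compound 1 `FC(F)(F)C(F)(F)C(F)(F)C(F)(F)C(F)(F)C(F)(F)CCn1cc(COc2ccccc2-c2nc3ccccc3s2)nn1`: 15100 nM
Compound 2 `Brc1ccc(-c2cc(COc3ccccc3-c3nc4ccccc4s3)on2)cc1`: 19200 nM
Compound 3 `COc1cc(-c2cc(COc3ccccc3-c3nc4ccccc4s3)on2)cc(OC)c1OC`: 22900 nM

Of the compounds shown here, three have been measured in a functional assay on A549 cells (Homo sapiens) for cytotoxicity, read by MTT assay, with a stated time of 24 h; a higher number here means a weaker inhibitor, a lower number a stronger inhibitor. Compound 1 holds the lowest of the three numbers, yet its gaps to compound 2 and to compound 3 both lie within the scatter, so the three cannot be placed in any order. Compound 4 `FC(F)(F)C(F)(F)C(F)(F)C(F)(F)C(F)(F)C(F)(F)C(F)(F)C(F)(F)CCn1cc(COc2ccccc2-c2nc3ccccc3s2)nn1` has not been measured. It differs from compound 1 in one place: 1,1,2,2,2-pentafluoroethyl in place of fluoro on a saturated chain carbon bound to two fluorine atoms and a saturated chain carbon. Among the compounds with values here, no pair of measured compounds covers a change of this kind, so compound 1 alone serves as the anchor. Within the data shown here, with nothing among the measured pairs to suggest otherwise, the step is expected to stay within the scatter, in no clear direction: a 1.2-fold lower number from compound 1 to compound 4 (0.07 log units; within the scatter). Compound 4 is therefore estimated at 13000 nM, with a range from 5000 nM to 35000 nM.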

Compound 4, half-maximal inhibitory concentration: 13100 nM
For compound 4 the middle estimate is 1.0-fold (0.00 log units) below the measured one; the measured number falls inside the stated range.
By their numbers in this assay, from the lowest: compounds 4, 1, 2 and 3 (each within the scatter of the next).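

In this assay, within the data shown here, 1,1,2,2,2-pentafluoroethyl in place of fluoro on a saturated chain carbon bound to two fluorine atoms and a saturated chain carbon gives a 1.2-fold lower number from compound 1 to compound 4 (0.06 log units; within the scatter) and so offers the first reading at this position. The fluorinated chain can thus be extended by this much without the number moving beyond the scatter, though this single step sets no trend. Whether a shorter fluorinated chain, a plain alkyl chain, or an amine or carboxylic acid at the chain end would behave alike remains open, and no measurement at hand explains the result.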